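Swapping an Ester for a Dimethylamino Group

This account rests on a few compounds, and the source may have more. Where it says the series, first, only, none or still open, it means among the compounds named here.

Compound 1 `COC(=O)c1cccc(C(=O)N2CCC(N(C3CC3)S(=O)(=O)c3cccc(C(F)(F)F)c3)CC2)c1` has the higher of the two measured numbers: in an assay on HEK293 cells for inhibition of Voltage-dependent N-type calcium channel subunit alpha-1B (Homo sapiens), read by FLIPR and calcium flux, in the presence of a further agent that is not named here (a lower number here means a stronger inhibitor, a higher number a weaker inhibitor), compound 1 gives 380 nM, while compound 2 `O=C(c1ccccc1OC(F)(F)F)N1CCC(N(C2CC2)S(=O)(=O)c2cccc(C(F)(F)F)c2)CC1` gives 120 nM. The step of a 3.2-fold lower number from compound 1 to compound 2 (0.50 log units; beyond the scatter) came from exchanging the whole aryl group on the carbonyl. Compound 3 `CN(C)c1cccc(C(=O)N2CCC(N(C3CC3)S(=O)(=O)c3cccc(C(F)(F)F)c3)CC2)c1` alters that same aryl group in a different way: dimethylamino in place of methoxycarbonyl on an aromatic carbon. Within the data shown here, no measured step tests this particular exchange, so only a modest shift, if any, is expected. The step of a 1.3-fold lower number from compound 1 to compound 3 (0.10 log units; within the scatter) is what is expected here. Compound 3 is estimated at 300 nM, within 100 nM to 900 nM.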

Compound 3, half-maximal inhibitory concentration: 240 nM
The estimate for compound 3 lay 1.3-fold (0.10 log units) above the measured number; low and high end bracket the measured number.
By their numbers in this assay, from the lowest: compounds 2, 3 and 1 (each within the scatter of the next, the first and the last beyond it).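

In this assay, the exchange of methoxycarbonyl for dimethylamino on this aromatic carbon gives a 1.6-fold lower number from compound 1 to compound 3 (0.20 log units; within the scatter) and so cannot be told from no change, even though the group that enters has no carbonyl and carries nitrogen instead of oxygen. The other new comparison, a 2.0-fold higher number from compound 2 to compound 3 (0.30 log units; within the scatter), also stays within the scatter, so compound 3 cannot be separated from either neighbour, although compound 1 and compound 2 are separated. No measurement here explains these results.

Going by these compounds, whether a carboxylic acid or a primary amine on this carbon would shift the number beyond the scatter remains open.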